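Methyl on the aniline nitrogen of a phthalimide aminomethyl series

The compounds below may be only part of what the source reports. "The series", "measured", "known", "first", "only" and "open" are said of these compounds alone.

The series rests on a shared core carrying an aminomethyl link to a substituted aromatic ring. Compound 1 `O=C1c2ccccc2C(=O)N1CNc1ccc(Cl)cc1` bears chloro on that ring, and in an assay on isolated protein for inhibition of ribosomal protein S6 kinase alpha-2 (Homo sapiens), read by fluorescence, with a stated time of 20 min, tested at 10 uM (a higher number here means more inhibition at the concentration tested (going by the name of the read-out), a lower number less inhibition), compound 1 gives 8.52%. Compound 2 `COc1ccc(NCN2C(=O)c3ccccc3C2=O)cc1` carries methoxy instead, and in this assay compound 2 gives 97.2%, the higher of the two numbers recorded. Within the data shown here, the single measured step, a number 88.7 percentage points higher from compound 1 to compound 2 (beyond the scatter), is a change on the aromatic ring.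

Compound 3 `COc1ccc(N(C)CN2C(=O)c3ccccc3C2=O)cc1` differs from compound 2 by methyl in place of hydrogen on a nitrogen on an aromatic ring. Among the measured compounds shown here, no measured step touches the nitrogen on the aromatic ring, so the one step in hand, large as it is, does not bear on this change; the expectation rests on the value of compound 2 alone and must be held with a wide range. A downward step of moderate size is expected, a number 37.2 percentage points lower from compound 2 to compound 3 (beyond the scatter), with the possibility of no change beyond the scatter kept open. Compound 3 is therefore estimated at 60% in this assay, within a range from 15% to 95%.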

Compound 3, a percentage reported as inhibition, at one concentration (the size of the read-out at that concentration, not a potency): 87%
For compound 3 the middle estimate is 27 percentage points below the measured one, within the range that was stated.
By their numbers in this assay, from the lowest: compound 1; then compound 3; then compound 2.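

In this assay, the change on this nitrogen gives a number 10.2 percentage points lower from compound 2 to compound 3 (beyond the scatter), so the nitrogen on the aromatic ring can carry methyl in place of hydrogen at a modest cost, and a hydrogen there is not needed for a high reading: compound 3 still gives 87%. The earlier step, a number 88.7 percentage points higher from compound 1 to compound 2 (beyond the scatter), concerned only the substituent on the aromatic carbon, and beside it the change on the nitrogen is much the smaller of the two. No evidence is available that bears on why methyl on this nitrogen lowers the number.

What an ethyl group or a longer chain on this nitrogen would do remains open, since methyl is the only group shown there in place of hydrogen. Going by these compounds, it is also open whether methyl on this nitrogen would give a step of similar size with chloro in place of methoxy on the aromatic ring, or with another group there such as an amine or a carboxylic acid.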